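From 3,3-dimethyloxiran-2-yl to isopropylcarbonyl on a shared core

The source may hold more compounds than are shown below. What is called first, only, known or untested is meant among the compounds shown, and "the series" means these compounds.

Of the compounds shown here, two with a shared core have so far been tested in a functional assay on MCF7 cells (Homo sapiens) for cytotoxicity, read by MTT assay, with a stated time of 48 h; a higher number here means a weaker inhibitor, a lower number a stronger inhibitor. Compound 1 (`C=CC(C)(O)CC[C@@H]1C(=C)CC[C@H](Br)[C@@]1(C)CCC(Br)C(C)(C)O`) gave > 100000 nM; 60700 nM (2 entries). Among the compounds with values here, compound 2 (`C=CC(C)(O)CC[C@@H]1C(=C)CC[C@H](Br)[C@@]1(C)CCC1OC1(C)C`) gave 71700 nM, and it is the only one of the pair with a single number.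

Compound 3 (`C=CC(C)(O)CC[C@@H]1C(=C)CC[C@H](Br)[C@@]1(C)CCC(=O)C(C)C`) has not yet been measured. It has the same atoms as compound 2, joined differently: isopropylcarbonyl in place of 3,3-dimethyloxiran-2-yl on a saturated chain carbon, two bonds along the chain from a saturated ring carbon. Isopropylcarbonyl stands in place of 3,3-dimethyloxiran-2-yl on a saturated chain carbon, two bonds along the chain from a saturated ring carbon.

Within the data shown here, no measured step shows what this change does, so nothing beyond the scatter is expected in this assay, and the expectation stays anchored on compound 2 at 71700 nM. The expected step is a 1.0-fold lower number from compound 2 to compound 3 (0.01 log units; within the scatter). Compound 3 is estimated at 70000 nM, with an expected range from 30000 nM to 150000 nM.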

Compound 3, half-maximal inhibitory concentration: > 100000 nM
Compound 3: a limit, no number; the forecaster's own chance of this, stated with the estimate: 25%; middle value at least 1.4-fold (0.15 log units) away from the limit.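

In this assay, within the data shown here, putting isopropylcarbonyl in place of 3,3-dimethyloxiran-2-yl on a saturated chain carbon, two bonds along the chain from a saturated ring carbon, gives the first step that can be read at this position: an at least 1.3-fold higher number from compound 2 to compound 3 (0.14 log units; that floor lies within the scatter). For compound 3, the entry > 100000 nM is a limit of the assay and not a number. The step is therefore only a floor, and it shows that this rearrangement of the same atoms, which opens the three-membered ring and brings in a carbonyl, does not bring the number down, with the reading resting at the edge of what the assay reports: the limit of > 100000 nM in this assay, at which 1 of the 3 values shown sits.

On these data alone, how far the true values of this small set lie apart remains open, since a limit and a number can stand side by side even for one compound: the several entries of compound 1 in this assay, > 100000 nM; 60700 nM (2 entries). The compounds shown also leave open whether an amine or a carboxylic acid at this place on the shared core would give a number clearly lower than those seen here.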